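From Fluorine to Chlorine on the Carbonyl Substituent

A few compounds are considered here, and "the series" means these few. Any claim that something is new, unique, unknown or untested is made for them only; others in the source may bear on it.

Compound 1 `O=C(NC(=S)NNc1ncnc2ccccc12)c1ccccc1F`: 4610 nM
Compound 2 `COc1cc2ncnc(NNC(=S)NC(=O)c3ccccc3F)c2cc1OC`: 12700 nM

In a functional assay on CNE-2 cells (Homo sapiens) for cytotoxicity, read by MTT assay, with a stated time of 72 h (on this read-out higher numbers stand for weaker inhibition and lower numbers for stronger inhibition), compound 1 gives 4610 nM, while compound 2 gives 12700 nM. Compound 2 thus stands at the highest of the two numbers, and its nearest neighbour, compound 1, lies beyond the scatter below it. Compound 3 `COc1cc2ncnc(NNC(=S)NC(=O)c3cccc(Cl)c3)c2cc1OC` differs from compound 2 in one place: 3-chlorophenyl in place of 2-fluorophenyl on a carbonyl carbon. Going by the values given here, no measured pair of compounds shows this exchange, so nothing here tells how the read-out responds to it, and the expectation for compound 3 rests on compound 2 alone. The step expected here, a 1.2-fold lower number from compound 2 to compound 3 (0.06 log units; within the scatter), is therefore one without a clear direction, most likely staying within the usual scatter, with a wide band of uncertainty on both sides. Compound 3 is estimated to give 11000 nM, within a range from 4000 nM to 30000 nM.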

Compound 3, half-maximal inhibitory concentration: 7460 nM
Beside the measured number, compound 3's estimate is 1.5-fold (0.17 log units) above it, within the range that was stated.
By their numbers in this assay, from the lowest: compounds 1, 3 and 2 (each within the scatter of the next, the first and the last beyond it).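

Going by these compounds alone, this step is the first reading of the substituent on the carbonyl carbon. In this assay, 3-chlorophenyl in place of 2-fluorophenyl gives a 1.7-fold lower number from compound 2 to compound 3 (0.23 log units; within the scatter), so this one exchange, made on the core shared by compound 2 and compound 3, leaves the read-out where repeated measurements could place it. A single step cannot separate the change of halogen from the change in where it sits on the phenyl ring, and nothing shown gives a reason for the result.

From the compounds shown here alone, it remains open whether an unsubstituted phenyl, an amine or a longer alkyl chain on this carbonyl carbon would also keep the read-out in this range. Going by these compounds, it is also open whether the same exchange on the core of compound 1 would give a similar step.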